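Losing a Methyl Group: Predicting Growth Inhibition for Compound 4

This account rests on a few compounds, and the source may have more. Where it says the series, first, only, none or still open, it means among the compounds named here.

Of the compounds shown here, three on a shared core have been measured. In a functional assay on OVCAR-3 cells (Homo sapiens) (on this read-out lower numbers stand for stronger inhibition of growth and higher numbers for weaker inhibition of growth), compound 1 `COc1ccc(-c2cc(O)c3cccnc3n2)cc1` gives 30200 nM, compound 2 `COc1cccc(-c2cc(O)c3c(C)cc(C)nc3n2)c1` gives 251 nM, and compound 3 `COc1ccc(-c2cc(O)c3cc(C)cnc3n2)cc1` gives 2950 nM. Compound 2 has the lowest number of the three. The difference between the cores of compound 2 and compound 3 is not broken down here. Between compound 3 and compound 1 the change is hydrogen in place of methyl on an aromatic carbon, and in this assay it gave a 10-fold higher number from compound 3 to compound 1 (1.01 log units; beyond the scatter). Compound 4 `COc1cccc(-c2cc(O)c3c(C)ccnc3n2)c1` is not yet measured; it differs from compound 2 by hydrogen in place of methyl on an aromatic carbon. This is the same kind of change, though here the place is next to the ring nitrogen and meta to a methyl group, whereas in compound 3 it is two atoms from the ring nitrogen. In this assay the step from compound 2 to compound 4 is expected to be an 8.0-fold higher number from compound 2 to compound 4 (0.90 log units; beyond the scatter), because the same kind of change in compound 3 produced a 10-fold higher number from compound 3 to compound 1 (1.01 log units; beyond the scatter). Compound 4 is therefore estimated at 2000 nM, most likely between 600 nM and 8000 nM.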

Compound 4, concentration for 50% growth inhibition: 25.7 nM
For compound 4 the middle estimate is 78-fold (1.89 log units) above the measured one, and the stated range ends above it.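

In this assay, hydrogen in place of methyl next to the ring nitrogen gave a 9.8-fold lower number from compound 2 to compound 4 (0.99 log units; beyond the scatter). For the compounds shown here, the same kind of change therefore moved the number in opposite directions on the two cores, so its effect did not carry from one to the other: the same change on two cores in this assay, a 10-fold higher number (1.01 log units; beyond the scatter) from compound 3 to compound 1 and a 9.8-fold lower number (0.99 log units; beyond the scatter) from compound 2 to compound 4, 100-fold (2.00 log units) apart, beyond the scatter of two such steps This does not show what produces the reversal, as each core supplies only one pair, and the two pairs differ both in the place of the change and in the rest of the molecule.

The compounds shown leave open how an amine or a longer chain would behave at the place next to the ring nitrogen. They also leave open what hydrogen in place of the remaining methyl group of compound 4 would do.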